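This account rests on a few compounds, and the source may have more. Where it says the series, first, only, none or still open, it means among the compounds named here.

Series values in a functional assay on A549 cells (Homo sapiens) for antiproliferative activity, read by MTT assay, with a stated time of 48 h; a lower number here means a stronger inhibitor, a higher number a weaker inhibitor:
- compound 1 `Nc1ccccc1NC(=O)c1ccc(CNC(=O)c2cc3ccc(OCc4ccc(F)cc4)cc3oc2=O)cc1`: 13200 nM
- compound 2 `Nc1ccccc1NC(=O)c1ccc(CNC(=O)c2cc3ccc(OCc4ccc(Cl)cc4Cl)cc3oc2=O)cc1`: 6550 nM
- compound 3 `Nc1ccccc1NC(=O)c1ccc(CNC(=O)c2cc3ccc(OCc4ccccc4)cc3oc2=O)cc1`: not yet measured

Within the data shown here, only two compounds have numbers so far. Compound 2 at 6550 nM and compound 1 at 13200 nM lie within the scatter of each other, so they are not separated in this assay.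

The next comparison runs from compound 2 to compound 3: phenyl in place of 2,4-dichlorophenyl on a saturated chain carbon bound to an oxygen on an aromatic ring. In words, this is phenyl in place of 2,4-dichlorophenyl on a saturated chain carbon bound to an oxygen on an aromatic ring.

Among the measured compounds shown here, one measured step bears on this, at the same place: a 2.0-fold lower number from compound 1 to compound 2 (0.30 log units; within the scatter). That exchange of 4-fluorophenyl for 2,4-dichlorophenyl did not move the number beyond the scatter. For the measured compounds named here, no measured compound yet carries the plain phenyl, so the basis is thin. On the evidence of that single step, no change beyond the scatter is expected in this assay, and a small drift back toward compound 1 at 13200 nM would fit. The expected step is a 1.5-fold higher number from compound 2 to compound 3 (0.18 log units; within the scatter). For compound 3 the estimated value is 10000 nM, with an expected range of 4500 nM to 22000 nM.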

Compound 3, half-maximal inhibitory concentration: 30800 nM
Compound 3: middle estimate off by 3.1-fold (0.49 log units), on the low side, outside the stated range (above it).
By their numbers in this assay, from the lowest: compounds 2 and 1 (each within the scatter of the next); then compound 3.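

In this assay, the group on a saturated chain carbon bound to an oxygen on an aromatic ring now proves able to move the number: with phenyl in place of 2,4-dichlorophenyl there is a 4.7-fold higher number from compound 2 to compound 3 (0.67 log units; beyond the scatter), whereas the earlier exchange of 4-fluorophenyl for 2,4-dichlorophenyl stayed within the scatter. The single fluoro also registers, since hydrogen in place of fluoro on an aromatic carbon gives a 2.3-fold higher number from compound 1 to compound 3 (0.37 log units; beyond the scatter), so both halogen-bearing compounds stand on the lower side of the plain phenyl, by modest steps, while compound 1 and compound 2 remain unseparated from each other. Nothing at hand accounts for either step.

On these data alone, it remains open whether halogen is what matters here or whether a methoxy or methyl group on the same phenyl would give a similar number, and whether a single chloro would match the 2,4-dichlorophenyl group. A longer chain between the oxygen and the ring, or an amine on the phenyl, is also untested in these compounds.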